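The source may report more compounds than this note shows. Statements on the series, on what has been measured and on what is new or still open speak of the compounds shown alone.

Measured in an ADME assay on L6 cells (Rattus norvegicus) for cytotoxicity, read by resazurin assay, with a stated time of 72 h; a lower number here means a stronger inhibitor, a higher number a weaker inhibitor:
- Compound 1 `OC(c1ccc(Cl)cc1)(c1cccnc1)c1ccccc1Cl`: 61300 nM
- Compound 2 `COC(c1ccc(Cl)cc1)(c1cccnc1)c1ccccc1Cl`: 58700 nM

Among the compounds with values here, with only two measured compounds, compound 1 stands level with compound 2, as a 1.0-fold lower number from compound 1 to compound 2 (0.02 log units; within the scatter) shows, so neither can be ranked above the other. The next compound, compound 3 `OC(c1ccc(Cl)cc1)(c1cccnc1)c1ccccc1C(F)(F)F`, keeps the core of compound 1 but carries trifluoromethyl in place of chloro on an aromatic carbon, ortho to a large group: trifluoromethyl in place of chloro on an aromatic carbon.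

Within the data shown here, no measured step covers this change. Among the measured compounds shown here, the single step available, a 1.0-fold lower number from compound 1 to compound 2 (0.02 log units; within the scatter), puts methyl in place of hydrogen on an oxygen, so it is only a loose guide. It does show one small edit leaving this assay unmoved, and nothing here points to a clear shift in either direction. The expected result is a 1.2-fold lower number from compound 1 to compound 3 (0.09 log units; within the scatter), which is no real change. Compound 3 is estimated at 50000 nM, with an expected range of 20000 nM to 110000 nM.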

Compound 3, half-maximal inhibitory concentration: 59300 nM
Compound 3: middle estimate off by 1.2-fold (0.07 log units), on the low side; low and high end bracket the measured number.
By their numbers in this assay, from the lowest: compounds 2, 3 and 1 (each within the scatter of the next).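

Replacing chloro with trifluoromethyl in this assay gives a 1.0-fold lower number from compound 1 to compound 3 (0.01 log units; within the scatter), so a second kind of edit also leaves the number unmoved. The earlier step touched only the oxygen, whereas this one shows that on an aromatic carbon, ortho to a large group, chloro with 1 heavy atom can give way to trifluoromethyl with 4 heavy atoms without any real change. Nothing available explains why the number holds steady here.

The compounds shown leave open whether a different kind of group at this same position, such as an amine or a carboxylic acid, would also leave the number unmoved. They also leave open whether any edit elsewhere on the core of compound 1 would produce a change beyond the scatter.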